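The source may report more compounds than this note shows. Statements on the series, on what has been measured and on what is new or still open speak of the compounds shown alone.

Compounds measured so far:

- compound 1 `Cc1cc(O)c(C2=NN(c3ccc(S(N)(=O)=O)cc3)C(c3ccccc3O)C2)cc1Cl` — 43100 nM
- compound 2 `Cc1cc(O)c(C2=NN(c3ccc(S(N)(=O)=O)cc3)C(c3ccccc3Cl)C2)cc1Cl` — 29400 nM
- compound 3 `Cc1cc(O)c(C2=NN(c3ccc(S(N)(=O)=O)cc3)C(/C=C/c3ccccc3)C2)cc1Cl` — 59400 nM

All three were tested in a functional assay on SN12C cells (Homo sapiens) for antiproliferative activity, with a stated time of 48 h; a lower number here means that less compound is tolerated, a higher number that more compound is tolerated. Compound 1 stands second highest of the three numbers. Its nearest neighbour is compound 3, reached by a 1.4-fold higher number from compound 1 to compound 3 (0.14 log units; within the scatter), and its furthest is compound 2, reached by a 1.5-fold lower number from compound 1 to compound 2 (0.17 log units; within the scatter); both of these steps stay within the scatter. Going by the values given here, the only step that goes beyond it is a 2.0-fold higher number from compound 2 to compound 3 (0.31 log units; beyond the scatter), and even that is modest.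

Compound 4 `COc1ccc(C2CC(c3cc(Cl)c(C)cc3O)=NN2c2ccc(S(N)(=O)=O)cc2)c(OC)c1OC` differs from compound 1 in one place: 2,3,4-trimethoxyphenyl in place of 2-hydroxyphenyl on a saturated ring carbon. The measured steps that bear on this are the two that alter the same saturated ring carbon, namely a 1.4-fold higher number from compound 1 to compound 3 (0.14 log units; within the scatter) and a 2.0-fold higher number from compound 2 to compound 3 (0.31 log units; beyond the scatter), together with a 1.5-fold lower number from compound 1 to compound 2 (0.17 log units; within the scatter), which changes the group on that carbon by only a single substituent. Across those three exchanges the numbers moved little, at most modestly. A change of this kind is therefore expected to give no step beyond the scatter, with a slight lean towards a higher number, as seen in a 1.4-fold higher number from compound 1 to compound 3 (0.14 log units; within the scatter).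

Compound 4 is accordingly estimated at 45000 nM, within a range of 18000 nM to 95000 nM, meaning an expected step of a 1.0-fold higher number from compound 1 to compound 4 (0.02 log units; within the scatter).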

Compound 4, concentration lethal to 50% of the cells: 35500 nM
The estimate for compound 4 lay 1.3-fold (0.10 log units) above the measured number, and the stated range covers the measured number.
By their numbers in this assay, from the lowest: compounds 2, 4, 1 and 3 (each within the scatter of the next, the first and the last beyond it).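

In this assay, the saturated ring carbon next to the ring nitrogen accepts a clearly bigger group with no step beyond the scatter: 2,3,4-trimethoxyphenyl, with 12 heavy atoms, replaces 2-hydroxyphenyl, with 7, and the hydrogen-bond donor of the hydroxy group is lost, yet the result is a 1.2-fold lower number from compound 1 to compound 4 (0.08 log units; within the scatter). Compound 4 also stays within the scatter of the other two compounds, with a 1.7-fold lower number from compound 3 to compound 4 (0.22 log units; within the scatter) and a 1.2-fold higher number from compound 2 to compound 4 (0.08 log units; within the scatter), even though these two lie just beyond the scatter of each other, as a 2.0-fold higher number from compound 2 to compound 3 (0.31 log units; beyond the scatter) shows. No measurement available here explains why such different groups leave the number almost unchanged.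

All the groups shown at this carbon are built around a phenyl ring, so it remains open whether a basic amine such as a piperidine, a carboxylic acid or a longer alkyl chain would also leave the number in the same range. The compounds shown also hold the 5-chloro-2-hydroxy-4-methylphenyl and 4-sulfamoylphenyl groups constant, so they cannot tell whether changes there would move the number further.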